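Swapping a benzyl for a butoxy on a urea-type scaffold

This account rests on a few compounds, and the source may have more. Where it says the series, first, only, none or still open, it means among the compounds named here.

Of the compounds shown here, three have been tested so far in a functional assay on HCT-116 cells (Homo sapiens) for inhibition, read by sulforhodamine B assay, with a stated time of 48 h; a lower number here means a stronger inhibitor of growth, a higher number a weaker inhibitor of growth. Compound 1, `O=C(Nc1ccccc1OC(F)(F)F)Nc1n[nH]c2ccccc12`, gives 16200 nM in this assay. Compound 2, `Nc1nn(C(=O)Nc2ccc(Cc3ccccc3)cc2)c2ccccc12`, gives 7030 nM in this assay. Compound 3, `COc1ccc(NC(=O)Nc2n[nH]c3ccccc23)cc1`, reaches only a limit of the assay in this assay, > 100000 nM, so no number is known for it; this is the limit described in the limit of > 100000 nM in this assay, at which 1 of the 3 values shown sits. Among the two actual numbers, compound 2 has the lower one, and the number of compound 1 stands higher by a margin beyond the usual scatter.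

Compound 4, `CCCCOc1ccc(NC(=O)n2nc(N)c3ccccc32)cc1`, has not yet been tested in this assay. It differs from compound 2 in one place: butoxy in place of benzyl on an aromatic carbon, para to a large group. Going by the values given here, no measured pair shows this exact change, so the expectation rests on compound 2 alone. A modest weakening is expected, since a ring is lost and a chain with an oxygen takes its place, yet not a large one. Compound 4 is therefore estimated at 15000 nM in this assay, within a range from 4000 nM to 60000 nM, which corresponds to an expected step of a 2.1-fold higher number from compound 2 to compound 4 (0.33 log units; beyond the scatter).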

Compound 4, concentration for 50% growth inhibition: 19900 nM
Compound 4: middle estimate off by 1.3-fold (0.12 log units), on the low side; the measured number falls inside the stated range.
By their numbers in this assay, from the lowest: compound 2; then compounds 1 and 4 (each within the scatter of the next). At a limit, above all of these: compound 3.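

Going by these compounds alone, at an aromatic carbon para to a large group, butoxy in place of benzyl gives a 2.8-fold higher number from compound 2 to compound 4 (0.45 log units; beyond the scatter) in this assay, the first measured step between two compounds that differ in only one place. The position is therefore not indifferent to this change, yet the step is modest, and the loss of a ring together with the arrival of a chain holding an oxygen still leaves compound 4 with a measured number, 19900 nM, rather than a limit of the assay. Nothing measured here gives a cause for this step.

This single step changes several things at once, so it cannot show whether the lost ring, the added oxygen or the chain itself accounts for the higher number. A phenoxy group would keep a ring alongside the oxygen and a pentyl chain would have no oxygen, so either one at this same place could begin to pull these features apart.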